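Swapping the Ester Tail: From Compound 2 to Compound 4

The source may report more compounds than this note shows. Statements on the series, on what has been measured and on what is new or still open speak of the compounds shown alone.

Compound 1, `CC(C)C(=O)OCOC(=O)C1=C(S[C@@H]2CN[C@H](C(=O)Nc3cccc(C(=O)OCOC(=O)C(C)C)c3)C2)[C@H](C)[C@@H]2[C@@H]([C@@H](C)O)C(=O)N12`, in an ADME assay for metabolic stability, read by LC-MS, with a stated time of 3 h, at pH 6.5, tested at 50 uM (a lower number here means that less of the compound is left, a higher number that more of the compound is left), gives > 95%, which is a limit of the assay and not a number.
Compound 2, `C[C@@H](O)[C@H]1C(=O)N2C(C(=O)OCOC(=O)C3CCCCC3)=C(S[C@@H]3CN[C@H](C(=O)Nc4cccc(C(=O)O)c4)C3)[C@H](C)[C@H]12`, gives > 95%, again only a limit.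
Compound 3, `C[C@@H](O)[C@H]1C(=O)N2C(C(=O)OCc3oc(=O)oc3C(C)(C)C)=C(S[C@@H]3CN[C@H](C(=O)Nc4cccc(C(=O)OCc5oc(=O)oc5C(C)(C)C)c4)C3)[C@H](C)[C@H]12`, gives > 95%, also a limit.

Compound 2 therefore stands where every measured compound stands: at the limit of > 95% in this assay, at which 3 of the 3 values shown sit. For the measured compounds named here, none of the three values is a number, so no compound can be placed ahead of or behind another, and no step between them can be sized. The three share the same core and differ only in the groups hung on its two ends.

Compound 4, `C[C@@H](O)[C@H]1C(=O)N2C(C(=O)OCC(F)(F)F)=C(S[C@@H]3CN[C@H](C(=O)Nc4cccc(C(=O)O)c4)C3)[C@H](C)[C@H]12`, has not been measured. It differs from compound 2 in one place: trifluoromethyl in place of (cyclohexylcarbonyl)oxy on a saturated chain carbon bound to an oxygen next to a carbonyl group. Going by the values given here, with every measured compound sitting at the limit, there is no measured step to guide the size or direction of this change, and the expectation is simply that compound 4 behaves like the others, with the step from compound 2 to compound 4 expected to be a number at least 2 percentage points lower from compound 2 to compound 4 (that floor lies within the scatter), nothing beyond the usual scatter. Compound 4 is thus estimated to reach 93%, within a range from 80% to 99%.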

Compound 4, percent of the compound remaining: > 95%
Compound 4: no number, only a limit; the forecaster's own chance of this, stated with the estimate: 70%; middle value at least 2 percentage points from the limit.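

Compound 4 gives > 95% in this assay, which is a limit of the assay and not a number. No step can be read between compound 2 and compound 4, because both sit at the same limit: the limit of > 95% in this assay, at which 4 of the 4 values shown sit.

As far as these compounds go, whether trifluoromethyl in place of (cyclohexylcarbonyl)oxy changes how much compound remains, and how the four compounds rank, stays open.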